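Lengthening the amide chain of compound 2

The source may hold more compounds than are shown below. What is called first, only, known or untested is meant among the compounds shown, and "the series" means these compounds.

Three compounds share one core and an octyl amide chain and differ only in the acyl group. Compound 1 `CCCCCCCCNC(=O)[C@@H](NC(=O)c1cc2ccccc2o1)[C@@H](C)O` gives 66500 nM in a functional assay on SiHa cells (Homo sapiens) for cytotoxicity, read by MTT assay, with a stated time of 48 h; a higher number here means a weaker inhibitor, a lower number a stronger inhibitor; compound 2 `CCCCCCCCNC(=O)[C@@H](NC(=O)/C=C/c1ccccc1)[C@@H](C)O` gives 41400 nM; compound 3 `C/C=C/C=C/C(=O)N[C@H](C(=O)NCCCCCCCC)[C@@H](C)O` gives 123000 nM. Compound 2 stands alongside compound 1, with a 1.6-fold lower number from compound 1 to compound 2 (0.21 log units; within the scatter), and apart from compound 3, with a 3.0-fold higher number from compound 2 to compound 3 (0.47 log units; beyond the scatter), while a 1.8-fold higher number from compound 1 to compound 3 (0.27 log units; within the scatter) completes the triangle.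

Compound 4 `CCCCCCCCCCCCNC(=O)[C@@H](NC(=O)/C=C/c1ccccc1)[C@@H](C)O` keeps the acyl group of compound 2 and changes the amide chain: butyl in place of hydrogen on a saturated chain carbon, eight bonds along the chain from an amide-type nitrogen. Among the measured compounds shown here, none of the measured steps touches this chain, so they give no direct guide; they only show that the acyl group alone moves the numbers by modest amounts. The estimate for compound 4 therefore leans on compound 2 and allows a generous range. Compound 4 is expected to show a 1.4-fold lower number from compound 2 to compound 4 (0.14 log units; within the scatter), a step not resolved from the scatter. Compound 4 is thus estimated at 30000 nM, between 10000 nM and 90000 nM.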

Compound 4, half-maximal inhibitory concentration: > 200000 nM
Compound 4: a limit, no number (the forecaster's own chance of this, stated with the estimate: 10%); middle value at least 6.6-fold (0.82 log units) away from the limit.
By their numbers in this assay, from the lowest: compounds 2, 1 and 3 (each within the scatter of the next, the first and the last beyond it). At a limit, above all of these: compound 4.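

Among the compounds shown here, the earlier compounds varied only the acyl group, so compound 4 gives the first reading of the amide chain in this assay: butyl in place of hydrogen at this position gives an at least 4.8-fold higher number from compound 2 to compound 4 (0.68 log units; beyond the scatter) and shows that the chain also moves the number. As far as these compounds go, the value of compound 4 is a limit and not a number, so the full size of this step remains unknown: the limit of > 200000 nM in this assay, at which 1 of the 4 values shown sits.

The compounds shown leave open whether the number rises gradually with chain length or abruptly, and a decyl chain on the same amide would test this. They also leave open whether the longer chain has the same outcome with the acyl groups of compound 1 and compound 3, and whether an amine or a carboxylic acid at the chain end would change the result.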